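This account rests on a few compounds, and the source may have more. Where it says the series, first, only, none or still open, it means among the compounds named here.

In an ADME assay on microsomes from liver (Canis lupus familiaris) for metabolic stability, read by LC-MS, using NADPH, with a stated time of 10 min, tested at 0.1 uM (a lower number here means slower removal, a higher number faster removal of the compound), compound 1 `CC1SC(c2cccc(C(=O)NCCCCc3ccccc3)c2)N(c2ccc(C3CC3)cc2)C1=O` gives 1750 mL.min-1.g-1. For the measured compounds named here, the only other measured compound, compound 2 `O=C(NCCCCc1ccccc1)c1cccc(C2SCC(=O)N2c2ccc(C3CC3)cc2)c1`, gives 1080 mL.min-1.g-1, and the two values lie within the scatter of each other. Compound 3 `COc1ccccc1N1C(=O)C(C)SC1c1cccc(C(=O)NCCCCc2ccccc2)c1` keeps the core of compound 1 and its methyl group, and the change is this: 2-methoxyphenyl in place of 4-cyclopropylphenyl on an amide-type nitrogen in a ring. Going by the values given here, the one measured step, a 1.6-fold lower number from compound 1 to compound 2 (0.21 log units; within the scatter), puts hydrogen in place of methyl on a saturated ring carbon. That is a different place from the present change, and the step stays within the scatter. Among the compounds with values here, no measured step touches the group on the amide-type nitrogen in a ring, so the data give no direction for this change, and no step beyond the scatter is expected in this assay. The expected change is a 1.2-fold lower number from compound 1 to compound 3 (0.07 log units; within the scatter). Compound 3 is estimated at 1500 mL.min-1.g-1, with an expected range from 650 mL.min-1.g-1 to 3300 mL.min-1.g-1.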

Compound 3, intrinsic clearance in microsomes: 1170 mL.min-1.g-1
Beside the measured number, compound 3's estimate is 1.3-fold (0.11 log units) above it; the range from low to high includes it.
By their numbers in this assay, from the lowest: compounds 2, 3 and 1 (each within the scatter of the next).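

For the compounds shown here, this is the first measured change to the group on the amide-type nitrogen in a ring, and in this assay it gives a 1.5-fold lower number from compound 1 to compound 3 (0.17 log units; within the scatter) in a single step. At this position, then, 4-cyclopropylphenyl can give way to 2-methoxyphenyl, which has one atom fewer and brings an oxygen and a hydrogen-bond acceptor, without the number leaving the scatter of this assay. No measurement at hand offers an explanation for this result.

The compounds shown leave open whether a group carrying an amine or a carboxylic acid on the amide-type nitrogen in a ring would move the number beyond the scatter. They also leave open how 2-methoxyphenyl behaves when hydrogen stands in place of the methyl group on the saturated ring carbon.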